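The compounds below may be only part of what the source reports. "The series", "measured", "known", "first", "only" and "open" are said of these compounds alone.

Measured so far:
compound 1 `O=C(/C=C/CN1CCCCC1)Nc1ccccc1`: 2.95 h
compound 2 `CCN(CC)C/C=C/C(=O)Nc1ccccc1`: 2.83 h

Both numbers come from an ADME assay for pharmacokinetics, read by LC-MS, in phosphate buffer, with a stated time of 120 min, at pH 7.4, tested at 1 uM, in the presence of a further agent that is not named here; a higher number here means that the compound lasts longer, a lower number that the compound disappears faster. In this assay compound 1 gives 2.95 h and compound 2 gives 2.83 h. Compound 2 stands lowest of the two numbers, with compound 1 as its nearest neighbour. The step of a 1.0-fold lower number from compound 1 to compound 2 (0.02 log units; within the scatter) lies within the scatter, so neither compound can be called longer-lived than the other on what is measured.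

Compound 3 `CN(C)C/C=C/C(=O)Nc1ccccc1` has not yet been measured in this assay. It differs from compound 2 by dimethylamino in place of diethylamino on a saturated chain carbon bound to a double-bonded chain carbon. For the measured compounds named here, the only measured step that bears on this position is a 1.0-fold lower number from compound 1 to compound 2 (0.02 log units; within the scatter), in which the amine at the saturated chain carbon was exchanged without the half-life moving beyond the scatter. With one exchange of the amine at this place already recorded without consequence, the expectation for the further exchange to dimethylamino is no step beyond the scatter in this assay, in either direction. Compound 3 is therefore estimated at 2.8 h, with a range of 1.5 h to 5.5 h. The step this estimate implies is expected to be a 1.0-fold lower number from compound 2 to compound 3 (0.00 log units; within the scatter).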

Compound 3, half-life: 1.93 h
Beside the measured number, compound 3's estimate is 1.5-fold (0.16 log units) above it; measured number inside the range.
By their numbers in this assay, from the lowest: compounds 3, 2 and 1 (each within the scatter of the next).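

In this assay, dimethylamino in place of diethylamino, going from 5 heavy atoms to 3 on a saturated chain carbon bound to a double-bonded chain carbon, gives a 1.5-fold lower number from compound 2 to compound 3 (0.17 log units; within the scatter), and dimethylamino in place of piperidin-1-yl gives a 1.5-fold lower number from compound 1 to compound 3 (0.18 log units; within the scatter). The earlier pair offered a single exchange at this place; the series now holds three amines there, and every step among them stays within the scatter, with no listed compound going against this. The half-life at this place therefore shows no measurable dependence on which of these three amines is attached, and nothing at hand bears on why the values fall as they do.

Still open, as far as these compounds go, is whether this tolerance extends to other groups at the same place, such as morpholin-4-yl, an amine carrying a hydrogen such as methylamino, or a carboxylic acid, and whether a longer chain leading to the amine would leave the half-life equally undisturbed. The three compounds also share the rest of their structure, so they leave open whether a change to the amide, the double bond or the rest of the shared core would move the half-life beyond the scatter.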